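Trading a 3-fluorophenoxy group for fluoro

The source may hold more compounds than are shown below. What is called first, only, known or untested is meant among the compounds shown, and "the series" means these compounds.

Compound 1 `C=CC(=O)NCc1coc(-c2c(N)ncnc2Nc2ccc(OCc3cccc(F)c3)c(Cl)c2)n1`: 0.75 h
Compound 2 `C=CC(=O)NCc1coc(-c2c(N)ncnc2Nc2ccc(Oc3cccc(F)c3)c(Cl)c2)n1`: > 1.66 h

These half-lives come from an in vitro ADME assay on microsomes from liver (Homo sapiens) for metabolic stability, tested at 5 uM; on this read-out higher numbers stand for a longer-lived compound and lower numbers for a shorter-lived compound. Compound 2 gives > 1.66 h, which is a limit of the assay and not a number. Compound 3 `C=CC(=O)NCc1coc(-c2c(N)ncnc2Nc2ccc(F)c(Cl)c2)n1` is not yet measured and differs from compound 2 by fluoro in place of 3-fluorophenoxy on an aromatic carbon. Within the data shown here, the only measured step, an at least 2.2-fold higher number from compound 1 to compound 2 (0.34 log units; beyond the scatter), swapped a different pair of groups, so it is just a loose guide. A moderate change of uncertain direction is expected. The estimated step is an at least 1.1-fold lower number from compound 2 to compound 3 (0.07 log units; that floor lies within the scatter). For compound 3 the expected half-life is 1.4 h, with an estimated range of 0.7 h to 2.8 h.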

Compound 3, half-life: 0.267 h
The estimate for compound 3 lay 5.2-fold (0.72 log units) above the measured number; the measured number lies below the stated range.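

Fluoro on the carbon ortho to a chloro group gives the shortest half-life of the three in this assay, with an at least 6.2-fold lower number from compound 2 to compound 3 (0.79 log units; beyond the scatter) and a 2.8-fold lower number from compound 1 to compound 3 (0.45 log units; beyond the scatter). So both 3-fluorophenoxy and (3-fluorobenzyl)oxy go with a longer half-life here than fluoro does, which comparing those two groups alone could not show. Compound 2 has only a limit, so its step is a floor: the limit of > 1.66 h in this assay, at which 1 of the 3 values shown sits.

As far as these compounds go, it remains open whether a small ether such as methoxy would behave like fluoro or like the larger groups. The data also leave open whether an unsubstituted phenoxy would match 3-fluorophenoxy.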